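Chloro in Place of Methyl on an Inactive Amide

This account rests on a few compounds, and the source may have more. Where it says the series, first, only, none or still open, it means among the compounds named here.

Compound 1 `COC(=O)[C@H](CCSC)NC(=O)c1ccc(NCc2cncn2Cc2ccccc2C)cc1-c1ccccc1` carries a 2-methylbenzyl group on its imidazole. In a functional assay on NIH3T3 cells (Mus musculus) (a higher number here means that more compound is needed for the effect, a lower number that less compound is needed), compound 1 gives > 10 uM, which is a limit of the assay and not a number. Among the compounds with values here, the only other measured compound, compound 2 `N#CCNC(=O)c1ccc(NCc2cncn2Cc2ccc(C#N)cc2)cc1-c1ccccc1`, differs from it in several places at once. In this assay compound 2 likewise gives > 10 uM, again a limit. Within the data shown here, both measured values therefore sit at the limit of > 10 uM in this assay, at which 2 of the 2 values shown sit, and no step between measured compounds can be read from them.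

Compound 3 `COC(=O)[C@H](CCSC)NC(=O)c1ccc(NCc2cncn2Cc2ccccc2Cl)cc1-c1ccccc1` is reached from compound 1 by a single change: chloro in place of methyl on an aromatic carbon. Among the measured compounds shown here, no measured step for a change of this kind exists here. Since compound 1 shows only its limit of > 10 uM in this assay, little movement is expected. The step from compound 1 to compound 3 is estimated as a step that the limit leaves unreadable from compound 1 to compound 3, none beyond the scatter. Compound 3 is expected to give about 15 uM in this assay, within 5 uM to 50 uM, most likely reported only as a limit.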

Compound 3, concentration for half-maximal effect: > 10 uM
Compound 3 was reported as a limit (the forecaster's own chance of this, stated with the estimate: 75%); the middle value is on the limit's open side.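

No step can be read between compound 1 and compound 3, because each shows only a limit of the assay: the limit of > 10 uM in this assay, at which 3 of the 3 values shown sit.

The compounds shown leave open what actual value in this assay either compound has, and so whether chloro in place of methyl changes it at all.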